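Bile acid receptor series: biaryl versus styryl linkers

The source may report more compounds than this note shows. Statements on the series, on what has been measured and on what is new or still open speak of the compounds shown alone.

Measured compounds:
compound 1 `COC(=O)/C=C/c1cccc(N(Cc2ccc(-c3cccc(Cl)c3)cc2)C(=O)C(C)C)c1` — 77 nM
compound 2 `COC(=O)/C=C/c1cccc(N(Cc2ccc(/C=C/c3cccc(Cl)c3)cc2)C(=O)C(C)C)c1` — 164 nM

In an assay on isolated protein with Bile acid receptor (Homo sapiens) as the target (on this read-out lower numbers stand for an effect already at smaller amounts and higher numbers for an effect only at larger amounts of compound), compound 2 gives the highest of the two numbers; its nearest neighbour, compound 1, sits lower by a 2.1-fold higher number from compound 1 to compound 2 (0.33 log units; beyond the scatter). Compound 3 `COC(=O)/C=C/c1cccc(N(Cc2ccc(-c3ccc(F)c(Cl)c3)cc2)C(=O)C(C)C)c1` differs from compound 2 by 3-chloro-4-fluorophenyl in place of 2-(3-chlorophenyl)ethenyl on an aromatic carbon. For the measured compounds named here, the only step that bears on this is the one from compound 1 to compound 2, which introduced the ethenyl-linked ring and gave a 2.1-fold higher number from compound 1 to compound 2 (0.33 log units; beyond the scatter); compound 3 removes that linker again and adds fluorine, a change with no measured precedent here. Compound 3 is therefore expected to return toward the level of compound 1, roughly a 2.1-fold lower number from compound 2 to compound 3 (0.31 log units; beyond the scatter), giving an estimate of 80 nM (range 35 nM to 180 nM).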

Compound 3, half-maximal effective concentration: 129 nM
For compound 3 the middle estimate is 1.6-fold (0.21 log units) below the measured one; the measured number falls inside the stated range.
By their numbers in this assay, from the lowest: compounds 1, 3 and 2 (each within the scatter of the next, the first and the last beyond it).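

In this assay, fluoro on the biaryl ring leaves the number within the scatter (a 1.7-fold higher number from compound 1 to compound 3 (0.22 log units; within the scatter)), so this aromatic carbon, para to a large group, accepts 3-chloro-4-fluorophenyl as well as 3-chlorophenyl. The swap from the ethenyl-linked ring also stays within the scatter (a 1.3-fold lower number from compound 2 to compound 3 (0.10 log units; within the scatter)), so compound 3 cannot be told apart from compound 1 or compound 2, although those two differ beyond it. Nothing available explains these numbers.

Open, going by these compounds, is whether a ring carrying an amine or a carboxylic acid in place of the halogens would keep the number in this range.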